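A few compounds are considered here, and "the series" means these few. Any claim that something is new, unique, unknown or untested is made for them only; others in the source may bear on it.

Of the compounds shown here, three sharing one core have been measured in a functional assay on PC-3 cells (Homo sapiens) for cytotoxicity, read by MTT assay, with a stated time of 48 h; on this read-out lower numbers stand for stronger inhibition and higher numbers for weaker inhibition. Compound 1 `CNCC(=O)N1N=C(c2cc3ccccc3oc2=O)CC1c1ccccc1` gives 2300 nM in this assay. Compound 2 `CCCNCC(=O)N1N=C(c2cc3ccccc3oc2=O)CC1c1ccccc1` gives 7270 nM, and compound 3 `CC1CCCN(CC(=O)N2N=C(c3cc4ccccc4oc3=O)CC2c2ccccc2)C1` gives 28300 nM. Compound 3 therefore stands highest of the three, with the weakest inhibition: there is a 3.9-fold higher number from compound 2 to compound 3 (0.59 log units; beyond the scatter) and a 12-fold higher number from compound 1 to compound 3 (1.09 log units; beyond the scatter). Between the two open-chain amines there is a 3.2-fold higher number from compound 1 to compound 2 (0.50 log units; beyond the scatter). Compound 4 `CN1CCN(CC(=O)N2N=C(c3cc4ccccc4oc3=O)CC2c2ccccc2)CC1` has not yet been measured in this assay; the change is 4-methylpiperazin-1-yl in place of 3-methylpiperidin-1-yl on a saturated chain carbon bound to a carbonyl carbon. Among the measured compounds shown here, no measured step swaps one ring amine for another; the steps ending at compound 3 only show that its ring amine gave higher numbers than the open-chain amines of compound 1 and compound 2. Compound 4 keeps a ring amine with the same count of heavy atoms, so its number in this assay is expected to stay close to that of compound 3, with a 1.4-fold lower number from compound 3 to compound 4 (0.15 log units; within the scatter) as the expected step, likely small and downward if anything. Compound 4 is estimated at 20000 nM, within an expected range from 6000 nM to 60000 nM.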

Compound 4, half-maximal inhibitory concentration: 25800 nM
Compound 4: middle estimate off by 1.3-fold (0.11 log units), on the low side; the measured number falls inside the stated range.
By their numbers in this assay, from the lowest: compound 1; then compound 2; then compounds 4 and 3 (each within the scatter of the next).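

Among the compounds shown here, this is the first swap of one ring amine for another at this place, on a saturated chain carbon bound to a carbonyl carbon. In this assay, 4-methylpiperazin-1-yl in place of 3-methylpiperidin-1-yl gives a 1.1-fold lower number from compound 3 to compound 4 (0.04 log units; within the scatter) so a second ring nitrogen at the same count of heavy atoms leaves the two compounds indistinguishable. The higher numbers are also not confined to 3-methylpiperidin-1-yl, with a 3.5-fold higher number from compound 2 to compound 4 (0.55 log units; beyond the scatter) and an 11-fold higher number from compound 1 to compound 4 (1.05 log units; beyond the scatter) as the steps from the open-chain amines, but nothing at hand explains this gap.

The compounds shown leave open whether an open-chain dimethylamino group would give numbers like those of the ring amines or like those of compound 1 and compound 2. They also leave open how a morpholin-4-yl or pyrrolidin-1-yl ring would behave at this place.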